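Epimer of Compound 1: Expected Clearance of Compound 4

A few compounds are considered here, and "the series" means these few. Any claim that something is new, unique, unknown or untested is made for them only; others in the source may bear on it.

In an ADME assay on microsomes from liver (Homo sapiens) for metabolic stability, read by LC-MS, using NADPH, with stated times of 10 min and 45 min, tested at 1 uM (a lower number here means slower removal, a higher number faster removal of the compound), compound 1 `Cc1cc(C)c(CN2CCc3c(Cl)cc([C@@H](CO)[C@@H]4CCCO4)c(Cl)c3C2=O)c(=O)[nH]1` gives 70.3 uL/min. Among the results gathered so far, this is the only single number. Compound 2 `COC(c1cc(Cl)c2c(c1Cl)C(=O)N(Cc1c(C)cc(C)[nH]c1=O)CC2)C1CCN(C(C)=O)CC1` comes with several entries in this assay, where compound 2 gives 50.3 uL/min; 92.6 uL/min (2 entries). Compound 3 `COc1cc(C)[nH]c(=O)c1CN1CCc2c(Cl)cc([C@@H](O)C3COC3)c(Cl)c2C1=O` reaches only a limit of the assay: in this assay compound 3 gives < 7 uL/min. The spread that repeated entries of one compound can show is seen in the several entries of compound 2 in this assay, 50.3 uL/min; 92.6 uL/min (2 entries), and the position of the limit at which one of the three values sits is given by the limit of < 7 uL/min in this assay, at which 1 of the 3 values shown sits. Compound 1 therefore stands between the entries of compound 2 and above the limit reached by compound 3.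

Compound 4 `Cc1cc(C)c(CN2CCc3c(Cl)cc([C@@H](CO)[C@H]4CCCO4)c(Cl)c3C2=O)c(=O)[nH]1` is the next compound to be measured in this assay. It differs from compound 1 as follows: the two compounds have the same atoms and bonds and differ only in configuration as drawn: 1 of 2 stereo elements differ; a stereocentre at a saturated ring carbon is drawn S in compound 1 and R in compound 4. Among the compounds with values here, no measured pair in this set differs in a single stereocentre alone, so there is no measured step to lean on for the size of this change. Given that the atoms and bonds are unchanged, the step from compound 1 to compound 4 in this assay is expected to be small, in either direction, and most likely not beyond the usual scatter, so that a 1.0-fold lower number from compound 1 to compound 4 (0.00 log units; within the scatter) is expected. For compound 4 in this assay the estimate is 70 uL/min, expected to lie between 35 uL/min and 140 uL/min.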

Compound 4, intrinsic clearance in a liver preparation (reported as CLH), per the amount of preparation that the assay uses: 43 uL/min
For compound 4 the middle estimate is 1.6-fold (0.21 log units) above the measured one; measured number inside the range.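

In this assay, within the data shown here, the only pair in this set that differs at a single stereocentre gives a 1.6-fold lower number from compound 1 to compound 4 (0.21 log units; within the scatter), so the earlier compounds offered no such reading and this step is the first measure of what this change does at the saturated ring carbon. Inverting that centre from the S drawing of compound 1 to the R drawing of compound 4 leaves the number inside the scatter, and the comparison isolates configuration alone, with nothing else to account for the small gap: the fact that compounds 1 and 4 differ only in the configuration as drawn. Entries of a single compound in this set lie at least as far apart as this pair, so the data do not separate the two configurations: the several entries of compound 2 in this assay, 50.3 uL/min; 92.6 uL/min (2 entries).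

What the compounds shown leave open is whether the other stereo element, drawn alike in compound 1 and compound 4, would give a step of similar size if it alone were inverted. They also leave open how the number would respond to an amine or a carboxylic acid in place of the saturated ring that carries this stereocentre.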